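Nitro in place of aromatic hydrogen: compound 2 to compound 3

A few compounds are considered here, and "the series" means these few. Any claim that something is new, unique, unknown or untested is made for them only; others in the source may bear on it.

Working notes on the chlorinated series in a functional assay on SW1573 cells (Homo sapiens) for antiproliferative activity; a higher number here means a weaker inhibitor of growth, a lower number a stronger inhibitor of growth. Of the compounds shown here, two have been measured so far. Compound 1 `CC(C)C[C@H]1C[C@@H](Cl)CCO1` carries no aromatic ring on the shared core. In this assay compound 1 gives > 100000 nM, which is a limit of the assay and not a number. Compound 2 `Cl[C@H]1CCO[C@@H](c2ccccc2)C1` carries an aromatic ring of carbon only on the same core. In this assay compound 2 gives > 100000 nM, again a limit of the assay and not a number. Among the compounds with values here, compound 2 thus stands where every value of the series stands, namely at the limit of > 100000 nM in this assay, at which 2 of the 2 values shown sit; no step between measured compounds is known, and no order of the two compounds can be read from these values.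

Compound 3 `O=[N+]([O-])c1ccc([C@H]2C[C@@H](Cl)CCO2)cc1` differs from compound 2 by nitro in place of hydrogen on an aromatic carbon, in words nitro in place of hydrogen on an aromatic carbon. Within the data shown here, no measured step is available to scale this change against. The step of a number no higher from compound 2 to compound 3 (the limit leaves the size open) is expected to stay within the scatter, with the result most likely again reaching only the limit of the assay. Compound 3 is estimated at 100000 nM, with a range from 30000 nM to 300000 nM.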

Compound 3, concentration for 50% growth inhibition: > 100000 nM
Compound 3 was reported as a limit; the forecaster's own chance of this, stated with the estimate: 75%; the middle value sits exactly at the limit.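

In this assay, within the data shown here, compound 3 gives > 100000 nM, a limit of the assay and not a number, and no step between compound 2 and compound 3 can be read from it. The compounds shown leave open whether nitro in place of hydrogen on an aromatic carbon alters growth inhibition, and how the compounds rank: the limit of > 100000 nM in this assay, at which 3 of the 3 values shown sit.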